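The source may hold more compounds than are shown below. What is called first, only, known or untested is meant among the compounds shown, and "the series" means these compounds.

Measured so far in an ADME assay on L02 cells (Homo sapiens) for antiproliferative activity, read by MTT assay, with a stated time of 48 h; on this read-out lower numbers stand for stronger inhibition and higher numbers for weaker inhibition:
- compound 1 `N#CC1=C(N)Oc2c(c3nc4ccccc4nc3c3ccccc23)C12C(=O)N(Cc1cnnn1-c1cccc(Cl)c1)c1ccccc12` gives 35200 nM
- compound 2 `Cc1ccc(-n2nncc2CN2C(=O)C3(C(C#N)=C(N)Oc4c3c3nc5ccccc5nc3c3ccccc43)c3ccccc32)cc1Cl` gives > 50000 nM, a limit of this assay
- compound 3 `CCOc1ccc(-n2nncc2CN2C(=O)C3(C(C#N)=C(N)Oc4c(N)cc5nc6ccccc6nc5c43)c3ccccc32)cc1` gives > 50000 nM, a limit of this assay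

Compound 3 thus stands at the limit of this assay, with no number of its own; the limit of > 50000 nM in this assay, at which 2 of the 3 values shown sit, shows where it sits among the three values. Compound 4 `COc1cc(-n2nncc2CN2C(=O)C3(C(C#N)=C(N)Oc4c(N)cc5nc6ccccc6nc5c43)c3ccccc32)c(OC)cc1Cl` is the next in the series and has not yet been measured. It differs from compound 3 in one place: 4-chloro-2,5-dimethoxyphenyl in place of 4-ethoxyphenyl on an aromatic nitrogen.

Within the data shown here, only one measured step exists, and it bears on this change loosely at best: an at least 1.4-fold higher number from compound 1 to compound 2 (0.15 log units; that floor lies within the scatter) concerns a methyl in place of hydrogen on an aromatic carbon of the ring on the aromatic nitrogen, not the present exchange of the whole ring. Since compound 3 is already at the limit, the step expected here is a number no higher from compound 3 to compound 4 (the limit leaves the size open), which is to say no movement beyond the scatter. Compound 4 is therefore estimated at 50000 nM in this assay, with a range from 20000 nM to 100000 nM, most likely reported again as a limit.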

Compound 4, half-maximal inhibitory concentration: > 50000 nM
Compound 4 gave a limit, no number; the forecaster's own chance of this, stated with the estimate: 70%; the middle value lies on the limit itself.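

In this assay, among these compounds, compound 3 and compound 4 both stand at a limit, and no step between them can be read. The compounds shown leave open whether 4-chloro-2,5-dimethoxyphenyl in place of 4-ethoxyphenyl on an aromatic nitrogen changes the read-out at all, and in which direction.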